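Adding a 3-aminopiperidinyl group to compound 3

The source may report more compounds than this note shows. Statements on the series, on what has been measured and on what is new or still open speak of the compounds shown alone.

Measured compounds:
- compound 1, `CCN(CC)CCN(C)c1ccc(Nc2cc(NC3CC3)n3ncc(C#N)c3n2)cc1NC(C)=O`: 27 uL/min
- compound 2, `CC(=O)Nc1cc(Nc2cc(NC3CC3)n3ncc(C#N)c3n2)ccc1NCCCO`: 17 uL/min
- compound 3, `CC(=O)Nc1cccc(Nc2cc(NC3CC3)n3ncc(C#N)c3n2)c1`: 26 uL/min

These three compounds share one core and were tested in an ADME assay on cells (Hepatocyte, Rattus norvegicus) for metabolic stability; a higher number here means faster removal of the compound, a lower number slower removal. Compound 3 gives 26 uL/min, the second highest of the three numbers; its nearest neighbour is compound 1, with a step of a 1.0-fold lower number from compound 1 to compound 3 (0.02 log units; within the scatter), and the furthest is compound 2, with a step of a 1.5-fold higher number from compound 2 to compound 3 (0.18 log units; within the scatter). Both steps lie within the scatter, so the three compounds cannot be told apart on these numbers.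

Compound 4, `CC(=O)Nc1cc(Nc2cc(NC3CC3)n3ncc(C#N)c3n2)ccc1N1CCC[C@@H](N)C1`, has not yet been measured. It differs from compound 3 in one place: 3-aminopiperidin-1-yl in place of hydrogen on an aromatic carbon.

Going by the values given here, two measured steps bear on this change, since both also swap a hydrogen on that aromatic carbon for a nitrogen-linked group. From compound 1 to compound 3 the number moved by a 1.0-fold lower number from compound 1 to compound 3 (0.02 log units; within the scatter), and from compound 2 to compound 3 by a 1.5-fold higher number from compound 2 to compound 3 (0.18 log units; within the scatter). Neither substituent at this carbon produced a step beyond the scatter. The expected step from compound 3 to compound 4 in this assay is therefore a 1.1-fold lower number from compound 3 to compound 4 (0.03 log units; within the scatter), with no direction beyond the scatter. Compound 4 is estimated at 24 uL/min, within a range from 12 uL/min to 48 uL/min.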

Compound 4, intrinsic clearance in a liver preparation (reported as CLH), per the amount of preparation that the assay uses: < 1 uL/min
Compound 4: no number, only a limit; the forecaster's own chance of this, stated with the estimate: 5%; middle value at least 24-fold (1.38 log units) away from the limit.
By their numbers in this assay, from the lowest: compounds 2, 3 and 1 (each within the scatter of the next). At a limit, below all of these: compound 4.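

In this assay compound 4 gives < 1 uL/min, and this is a limit of the assay, not a number: the limit of < 1 uL/min in this assay, at which 1 of the 4 values shown sits.

The earlier compounds shown here made this aromatic carbon, ortho to an acetamido group and para to a large group, look insensitive, with hydrogen, (3-hydroxypropyl)amino and (2-(diethylamino)ethyl)(methyl)amino all within the scatter of one another, yet 3-aminopiperidin-1-yl gives an at least 26-fold lower number from compound 3 to compound 4 (1.41 log units; beyond the scatter), an at least 17-fold lower number from compound 2 to compound 4 (1.23 log units; beyond the scatter) and an at least 27-fold lower number from compound 1 to compound 4 (1.43 log units; beyond the scatter). All three steps lie beyond the scatter, and each is a minimum size, with the real gap possibly larger. Compounds 1 and 2 also carry a nitrogen-linked group at this carbon, so a nitrogen attachment alone does not go with the low number; the result depends on which group is attached.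

The compounds shown do not tell whether the low number goes with the six-membered ring, its amine or the defined stereocentre, and a plain piperidin-1-yl, a 3-hydroxypiperidin-1-yl or the mirror-image 3-aminopiperidin-1-yl would help separate these. As far as these compounds go, how far the true value of compound 4 lies past its limit also stays open.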